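Nitrooxy cinnamate esters: from compound 3 to compound 4

A few compounds are considered here, and "the series" means these few. Any claim that something is new, unique, unknown or untested is made for them only; others in the source may bear on it.

Measured so far in a functional assay on M4E cells (Homo sapiens) for cytotoxicity, read by resazurin assay, with a stated time of 72 h; a lower number here means a stronger inhibitor, a higher number a weaker inhibitor:
compound 1, `COc1cc(/C=C/C(=O)OC(C)CCOc2no[n+]([O-])c2S(=O)(=O)c2ccccc2)ccc1O`: 1180 nM
compound 2, `O=C(/C=C/c1ccc(OCCCCCO[N+](=O)[O-])c(O)c1)OCCCCCO[N+](=O)[O-]`: a limit, > 50000 nM
compound 3, `COc1cc(/C=C/C(=O)OC/C=C/CO[N+](=O)[O-])ccc1O`: 9380 nM

In this assay compound 3 gives 9380 nM, the highest of the two numbers recorded. The nearest number belongs to compound 1, which gives 1180 nM, a gap beyond the usual scatter. For compound 2 only a limit is recorded, > 50000 nM, which is the limit of > 50000 nM in this assay, at which 1 of the 3 values shown sits. Compound 2 therefore contributes no number to compare against.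

Compound 4, `COc1cc(/C=C/C(=O)OCCCO[N+](=O)[O-])ccc1O`, differs from compound 3 at one place: a group of 6 heavy atoms (2 carbon, 1 nitrogen, 3 oxygen; no ring) in place of a group of 7 heavy atoms (3 carbon, 1 nitrogen, 3 oxygen; no ring), on a saturated chain carbon bound to an oxygen next to a carbonyl group. Going by the values given here, no step between two measured compounds runs over a change of this kind, so the size of the step has no direct precedent here. The nitrooxy group and the ester remain; only the chain between them is shortened and loses its double bond. Such a change is expected to leave the number of compound 4 close to that of compound 3, with no direction beyond the scatter.

Compound 4 is therefore expected to give about 10000 nM in this assay, with a range from 3500 nM to 30000 nM. That estimate means an expected step of a 1.1-fold higher number from compound 3 to compound 4 (0.03 log units; within the scatter), inside the scatter.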

Compound 4, half-maximal inhibitory concentration: 18400 nM
Compound 4: middle estimate off by 1.8-fold (0.26 log units), on the low side; the range from low to high includes it.
By their numbers in this assay, from the lowest: compound 1; then compounds 3 and 4 (each within the scatter of the next). At a limit, above all of these: compound 2.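

In this assay, going by these compounds alone, this is the only step read at this position: 2-(nitrooxy)ethyl replaces the group of 7 heavy atoms with 2 double bonds outside aromatic rings, on a saturated chain carbon bound to an oxygen next to a carbonyl group, and gives a 2.0-fold higher number from compound 3 to compound 4 (0.29 log units; within the scatter). Within this one pair, then, the shorter chain without its chain double bond does not move the number beyond the scatter, and the nitrooxy group and the ester stay in place throughout. Nothing measured in the series explains the size of this step or ties it to a property of either group.

The two alterations travel together in this pair, so the compounds shown do not separate any contribution of chain length from that of the chain double bond, and a saturated chain carrying the same number of carbons as the group in compound 3 would be the direct test. A longer chain, or a chain ending in a hydroxyl group or an amine in place of the nitrooxy group, would show whether this tolerance extends further along the ester chain and whether the nitrooxy group matters here at all.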